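This account rests on a few compounds, and the source may have more. Where it says the series, first, only, none or still open, it means among the compounds named here.

Measured so far in an assay on cells for binding affinity to vitamin D3 receptor (Homo sapiens), read by fluorescence, tested at 1 uM; on this read-out higher numbers stand for more inhibition at the one concentration tested (going by the name of the read-out) and lower numbers for less inhibition:

Compound 1 `CCC(CC)(c1ccc(OS(=O)(=O)c2ccc(C)cc2)c(C)c1)c1ccc(OCC(=O)C(C)(C)C)c(OCC(=O)C(C)(C)C)c1` gives 35%.
Compound 2 `CCC(CC)(c1ccc(OS(=O)(=O)c2ccc(C)cc2)c(C)c1)c1ccc(OCC(O)C(C)(C)C)c(OCC(O)C(C)(C)C)c1` gives 43%.
Compound 3 `CCC(CC)(c1ccc(OCCO)c(C)c1)c1ccc(OCC(O)C(C)(C)C)c(OCC(O)C(C)(C)C)c1` gives 38%.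

All three numbers lie within the usual scatter of one another, so compound 3 cannot be set apart from compound 1 or compound 2 on this assay. Compound 4 `CCC(CC)(c1ccc(OCCCCO)c(C)c1)c1ccc(OCC(O)C(C)(C)C)c(OCC(O)C(C)(C)C)c1` is not yet measured; it differs from compound 3 by 2-hydroxyethyl in place of hydroxy on a saturated chain carbon, two bonds along the chain from an oxygen on an aromatic ring. Among the compounds with values here, the only measured step at the same oxygen on an aromatic ring is a number 5 percentage points lower from compound 2 to compound 3 (within the scatter), a swap of a much larger group that left the number within the scatter. A small extension at the same place is therefore expected to give no step beyond the scatter in this assay; the estimated step is no change at the digits printed from compound 3 to compound 4 (within the scatter). Compound 4 is expected to give about 38%, within 27% to 49%.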

Compound 4, a percentage reported as inhibition, at one concentration (the size of the read-out at that concentration, not a potency): 71%
The estimate for compound 4 lay 33 percentage points below the measured number; the whole stated range lies below it.
By their numbers in this assay, from the lowest: compounds 1, 3 and 2 (each within the scatter of the next); then compound 4.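

Going from 2-hydroxyethoxy to 4-hydroxybutoxy on this oxygen in this assay gives a number 33 percentage points higher from compound 3 to compound 4 (beyond the scatter) and so shows that this position responds to a change of chain length. Replacing (4-methylphenyl)sulfonyl with 4-hydroxybutyl on the same oxygen gives a number 28 percentage points higher from compound 2 to compound 4 (beyond the scatter) while replacing it with 2-hydroxyethyl gives a number 5 percentage points lower from compound 2 to compound 3 (within the scatter) and so removing the sulfonyl group does not by itself move the number beyond the scatter. Nothing available explains the step.

As far as these compounds go, whether 3-hydroxypropyl or a longer chain follows the same trend remains open. So does whether an amine or a carboxylic acid can replace the hydroxy of the 4-hydroxybutyl group.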